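The compounds below may be only part of what the source reports. "The series", "measured", "known", "first", "only" and "open" are said of these compounds alone.

Series notes. Compound 1 `CCCN1CCN(CCNC(=O)n2c(=O)n(C3CC3)c3ccccc32)CC1` is the reference point. In a functional assay for antagonist activity at 5-hydroxytryptamine receptor 4 (Cavia porcellus) (on this read-out lower numbers stand for lower potency and higher numbers for higher potency (the scale is a negative logarithm)), compound 1 gives 7.46. Compound 2 `CN1CCN(CCNC(=O)n2c(=O)n(C)c3ccccc32)CC1` is the other member with a result so far. In this assay compound 2 gives only a limit of < 6, not a number. Within the data shown here, of the two values shown, compound 1 therefore carries the only number; the second result sits at a limit, as noted in the limit of < 6 in this assay, at which 1 of the 2 values shown sits. Among the measured compounds shown here, compound 1 and compound 2 differ in more than one place, and no step between measured compounds is available: their two values show only that compound 1 has a number where compound 2 has a limit.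

Compound 3 `CCCCN1CCN(CCNC(=O)n2c(=O)n(C3CC3)c3ccccc32)CC1` is the next compound. It differs from compound 1 by methyl in place of hydrogen on a saturated chain carbon, three bonds along the chain from an amine nitrogen in a ring. For the measured compounds named here, no measured step of this kind exists, and the expected change is estimated at a number 0.06 log units lower from compound 1 to compound 3 (within the scatter), a shift not expected to exceed the usual scatter in either direction. Compound 3 is estimated at 7.4 in this assay, with a range from 6.9 to 7.9.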

Compound 3, negative logarithm of the antagonist equilibrium constant: 7.51
Estimate against measurement, compound 3: 0.11 log units below; low and high end bracket the measured number.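

Methyl in place of hydrogen on a saturated chain carbon, three bonds along the chain from an amine nitrogen in a ring, turns propyl into butyl and gives the series its first readable step in this assay: the step is a number 0.05 log units higher from compound 1 to compound 3 (within the scatter). At this position, butyl and propyl therefore give values that cannot be told apart on this read-out, so the extension is tolerated here. No measured property in the series bears on this result.

On these data alone, whether pentyl, a branched chain such as isopropyl, or a hydroxyl or amine at the chain end would hold this level remains open. Compound 2 gives < 6, a limit of the assay, and its step from compound 1 cannot be read, as the two differ in more than one place.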